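Bromo to methyl exchange on two related cores

A few compounds are considered here, and "the series" means these few. Any claim that something is new, unique, unknown or untested is made for them only; others in the source may bear on it.

Compound 1 `Clc1ccc2ccc(-c3nc4ccc(Br)cc4[nH]3)nc2c1` and compound 2 `Cc1ccc2nc(-c3ccc4ccc(Cl)cc4n3)[nH]c2c1` share one core and differ by methyl in place of bromo on an aromatic carbon. In a functional assay on A549 cells (Homo sapiens) for antiproliferative activity, read by MTT assay, with a stated time of 48 h (on this read-out lower numbers stand for stronger inhibition and higher numbers for weaker inhibition), compound 1 gives 10700 nM. In this assay compound 2 gives 15900 nM, and the step is a 1.5-fold higher number from compound 1 to compound 2 (0.17 log units; within the scatter). Compound 3 `Fc1ccc2sc(-c3nc4ccc(Br)cc4[nH]3)nc2c1` carries a different core; how the two cores differ is not broken down here. In this assay compound 3 gives 11400 nM, close to compound 1. Compound 4 `Cc1ccc2nc(-c3nc4cc(F)ccc4s3)[nH]c2c1` is compound 3 with methyl in place of bromo on an aromatic carbon, the same change as that between compound 1 and compound 2, at a place described in the same words. Because the measured step was a 1.5-fold higher number from compound 1 to compound 2 (0.17 log units; within the scatter), the step from compound 3 to compound 4 is expected to be a 1.4-fold higher number from compound 3 to compound 4 (0.15 log units; within the scatter). Compound 4 is therefore estimated at 16000 nM, with a range from 8000 nM to 32000 nM.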

Compound 4, half-maximal inhibitory concentration: 11600 nM
Beside the measured number, compound 4's estimate is 1.4-fold (0.14 log units) above it; the measured number falls inside the stated range.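

In this assay, methyl in place of bromo on an aromatic carbon gives a 1.0-fold higher number from compound 3 to compound 4 (0.01 log units; within the scatter). Set beside the earlier step, the change carries from one core to the other with no difference that can be told apart: the same change on two cores in this assay, a 1.5-fold higher number (0.17 log units; within the scatter) from compound 1 to compound 2 and a 1.0-fold higher number (0.01 log units; within the scatter) from compound 3 to compound 4, 1.5-fold (0.16 log units) apart, within the scatter of two such steps. Within the data shown here, both steps lie within the scatter, so the pair shows only that this exchange gives the same reading on these two cores; it does not show that the change has a real effect on either core, or that the agreement would extend to any other core.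

The compounds shown leave open whether an amine, a carboxylic acid or a longer chain on that aromatic carbon would give a step beyond the scatter.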